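This account rests on a few compounds, and the source may have more. Where it says the series, first, only, none or still open, it means among the compounds named here.

Compound 1 `C/C(=C\CC/C(C)=C/CC[C@@H]1[C@@]2(C)CCC(=O)C(C)(C)[C@H]2CC[C@@]1(C)O)CC/C=C(\C)C(=O)OCc1cn(-c2ccc(F)c(Cl)c2)nn1`, compound 2 `C/C(=C\CC/C(C)=C/CC[C@@H]1[C@@]2(C)CCC(=O)C(C)(C)[C@H]2CC[C@@]1(C)O)CC/C=C(\C)C(=O)OCc1cn(-c2cccc(Cl)c2)nn1` and compound 3 `C/C(=C\CC/C(C)=C/CC[C@@H]1[C@@]2(C)CCC(=O)C(C)(C)[C@H]2CC[C@@]1(C)O)CC/C=C(\C)C(=O)OCc1cn(-c2ccccc2)nn1` share one core and differ only in the group on the aromatic nitrogen. In a functional assay on A549 cells (Homo sapiens) for antiproliferative activity, read by MTT assay, with a stated time of 48 h (a lower number here means a stronger inhibitor, a higher number a weaker inhibitor), compound 2 gives 147000 nM. For compound 1 the assay reports only a limit, > 150000 nM. For compound 3 the assay likewise reports only a limit, > 150000 nM. The core of compound 3 differs from that of compound 2 by hydrogen in place of chloro on an aromatic carbon, a step of an at least 1.0-fold higher number from compound 2 to compound 3 (0.00 log units; that floor lies within the scatter). The change fluoro in place of hydrogen on an aromatic carbon produced an at least 1.0-fold higher number from compound 2 to compound 1 (0.00 log units; that floor lies within the scatter), against (the limit of > 150000 nM in this assay, at which 2 of the 3 values shown sit). Compound 4 `C/C(=C\CC/C(C)=C/CC[C@@H]1[C@@]2(C)CCC(=O)C(C)(C)[C@H]2CC[C@@]1(C)O)CC/C=C(\C)C(=O)OCc1cn(-c2cccc(F)c2)nn1` carries the same kind of change on compound 3, (fluoro in place of hydrogen on an aromatic carbon), though its place is meta to a large group rather than ortho to a chloro group and para to a large group. Resting on an at least 1.0-fold higher number from compound 2 to compound 1 (0.00 log units; that floor lies within the scatter), compound 4 is expected to show a number no higher from compound 3 to compound 4 (the limit leaves the size open). Compound 4 is estimated at 150000 nM in this assay.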

Compound 4, half-maximal inhibitory concentration: 124000 nM
Compound 4: middle estimate off by 1.2-fold (0.08 log units), on the high side; the range from low to high includes it.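

In this assay, fluoro in place of hydrogen on the phenyl of compound 3 gives an at least 1.2-fold lower number from compound 3 to compound 4 (0.08 log units; that floor lies within the scatter), while the neighbouring comparisons give a 1.2-fold lower number from compound 2 to compound 4 (0.07 log units; within the scatter) and an at least 1.2-fold lower number from compound 1 to compound 4 (0.08 log units; that floor lies within the scatter). Set beside the earlier fluoro step, the change reads: the same change on two cores in this assay, an at least 1.0-fold higher number (0.00 log units; that floor lies within the scatter) from compound 2 to compound 1 and an at least 1.2-fold lower number (0.08 log units; that floor lies within the scatter) from compound 3 to compound 4; the limit leaves it open whether they differ All of these steps or their floors lie within the scatter, so the values show no clear effect of the change on either core and do not show whether it carries from one core to the other, with many of the readings resting on a limit: the limit of > 150000 nM in this assay, at which 2 of the 4 values shown sit.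

Going by these compounds, it remains open whether a methoxy group, an amine or a carboxylic acid on the phenyl would give a value clear of that limit. On these data alone, it also remains open whether an amide in place of the ester would do so.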